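The source may report more compounds than this note shows. Statements on the series, on what has been measured and on what is new or still open speak of the compounds shown alone.

Compound 3 `CSc1c(SCC#CCO)cnc2ccccc12` shows the highest number among the three measured compounds in a functional assay on SW707 cells (Homo sapiens) for cytotoxicity, read by sulforhodamine B assay, with a stated time of 72 h; a lower number here means a stronger inhibitor, a higher number a weaker inhibitor: compound 3 gives 69.3 ug/mL. Compound 1 `OCC#CCSc1cnc2ccccc2c1Cl` gives 6.2 ug/mL, and compound 2 `OCC#CCSc1cnc2ccccc2c1SCC#CCO` gives 32 ug/mL. The step of an 11-fold higher number from compound 1 to compound 3 (1.05 log units; beyond the scatter) is large, while the steps of a 5.2-fold higher number from compound 1 to compound 2 (0.71 log units; beyond the scatter) and a 2.2-fold higher number from compound 2 to compound 3 (0.34 log units; beyond the scatter) are modest; all three lie beyond the scatter. Compound 4 `COc1c(SCC#CCO)cnc2ccccc12` differs from compound 3 in one place: methoxy in place of methylsulfanyl on an aromatic carbon. Among the compounds with values here, no measured step exchanges a sulfur-bearing group for an oxygen-bearing one at this aromatic carbon; the measured steps show only that replacement at this position can move the numbers, as in an 11-fold higher number from compound 1 to compound 3 (1.05 log units; beyond the scatter), where methylsulfanyl took the place of chloro. Within the data shown here, with no direct precedent among the measured compounds, the expectation for compound 4 is a step of a 1.3-fold lower number from compound 3 to compound 4 (0.10 log units; within the scatter) that stays within the scatter, carrying a wide range. Compound 4 is therefore estimated at 55 ug/mL, between 20 ug/mL and 150 ug/mL.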

Compound 4, concentration for 50% inhibition: 67.4 ug/mL
Compound 4: middle estimate off by 1.2-fold (0.09 log units), on the low side, within the range that was stated.
By their numbers in this assay, from the lowest: compound 1; then compound 2; then compounds 4 and 3 (each within the scatter of the next).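

In this assay, within the data shown here, the step of a 1.0-fold lower number from compound 3 to compound 4 (0.01 log units; within the scatter) is the first direct exchange of a sulfur-bearing group for an oxygen-bearing one on this aromatic carbon, and it shows that methoxy and methylsulfanyl cannot be told apart here. The move away from chloro is therefore not tied to sulfur: an 11-fold higher number from compound 1 to compound 4 (1.04 log units; beyond the scatter) is large, and a 2.1-fold higher number from compound 2 to compound 4 (0.32 log units; beyond the scatter) is modest, so compound 4 repeats the position that compound 3 already held against both. Nothing available explains why the two groups read alike.

The compounds shown leave open whether a bromine atom, an amine or a longer alkoxy chain on this carbon would stay near compound 1 at 6.2 ug/mL or join compound 3 and compound 4. They also leave open whether methoxy and methylsulfanyl would still read alike with a different chain on the neighbouring sulfur-bearing group's place in the core.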